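Changing the Side Chain on Compound 1

The source may hold more compounds than are shown below. What is called first, only, known or untested is meant among the compounds shown, and "the series" means these compounds.

Compound 1 `NC(=O)C1CCN(Cc2ccc([C@H]3CC[C@]4(CC3)OOC3(O4)C4CC5CC(C4)CC3C5)cc2)CC1` was tested in an ADME assay on microsomes from liver (Homo sapiens) for metabolic stability, read by LC-MS, tested at 1 uM (on this read-out lower numbers stand for slow clearance and higher numbers for fast clearance), where compound 1 gives 10 mL.min-1.g-1. Going by the values given here, of the two numbers measured so far this is the smaller, but only by a gap within the scatter. Compound 2 `c1cc([C@H]2CC[C@]3(CC2)OOC2(O3)C3CC4CC(C3)CC2C4)ccc1OC1CCNCC1` gives 15 mL.min-1.g-1 in this assay, and the step of a 1.5-fold higher number from compound 1 to compound 2 (0.18 log units; within the scatter) shows that swapping the side chain on that aromatic carbon left the read-out essentially unchanged. Compound 3 `O[C@H]1CC[C@H](NCCCOc2ccc([C@H]3CC[C@]4(CC3)OOC3(O4)C4CC5CC(C4)CC3C5)cc2)CC1` has not yet been measured; it differs from compound 1 in one place: 3-((4-hydroxycyclohexyl)amino)propoxy in place of (4-carbamoylpiperidin-1-yl)methyl on an aromatic carbon. Among the compounds with values here, the only measured step that bears on this change is the one from compound 1 to compound 2, which stayed within the scatter. Within the data shown here, no measured compound carries the group that enters here, so the expectation rests on that single step, and a change of no more than the scatter is expected, a 1.3-fold higher number from compound 1 to compound 3 (0.11 log units; within the scatter). Compound 3 is therefore expected to give about 13 mL.min-1.g-1 in this assay, with a likely range from 6 mL.min-1.g-1 to 30 mL.min-1.g-1.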

Compound 3, intrinsic clearance in microsomes: < 7 mL.min-1.g-1
Compound 3 gave a limit, no number; the forecaster's own chance of this, stated with the estimate: 5%; at least 1.8-fold (0.26 log units) between middle value and limit.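

In this assay compound 3 gives a limit of the assay rather than a number: the limit of < 7 mL.min-1.g-1 in this assay, at which 1 of the 3 values shown sits. The new side chain, 3-((4-hydroxycyclohexyl)amino)propoxy, sits on the same aromatic carbon, para to a large group, and the step is an at least 1.4-fold lower number from compound 1 to compound 3 (0.15 log units; that floor lies within the scatter), so this floor alone does not separate the change from the scatter. The other step is an at least 2.1-fold lower number from compound 2 to compound 3 (0.33 log units; beyond the scatter), the first shown at this position to pass beyond the scatter, so changing the side chain here can shift the read-out and this larger group brings no rise in clearance.

The true value of compound 3 stays unknown, and the compounds shown do not separate the effect of the propoxy chain from that of the 4-hydroxycyclohexyl amine. As far as these compounds go, how a shorter ethoxy chain or a dimethylamino group at the chain end would read also remains open.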